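Thienopyrimidine ether paired with a difluorophenyl pyridazinone

The compounds below may be only part of what the source reports. "The series", "measured", "known", "first", "only" and "open" are said of these compounds alone.

Measured so far:
compound 1 `CNC(=O)c1cc(Oc2ccc(NC(=O)c3nn(-c4ccc(Br)cc4F)c(=O)cc3C)cc2F)ccn1`: 7930 nM in a functional assay on A549 cells (Homo sapiens) for cytotoxicity, read by MTT assay, with a stated time of 72 h; on this read-out lower numbers stand for stronger inhibition and higher numbers for weaker inhibition
compound 2 `Cc1cc(=O)n(-c2ccc(Br)cc2F)nc1C(=O)Nc1ccc(Oc2ncnc3ccsc23)c(F)c1`: 2980 nM in this assay

Within the data shown here, compound 2 holds the lowest of the two numbers; the single measured step, a 2.7-fold lower number from compound 1 to compound 2 (0.43 log units; beyond the scatter), exchanges the group on the ether oxygen. Compound 3 `Cc1cc(=O)n(-c2ccc(F)c(F)c2)nc1C(=O)Nc1ccc(Oc2ncnc3ccsc23)c(F)c1` differs from compound 2 by 3,4-difluorophenyl in place of 4-bromo-2-fluorophenyl on an aromatic nitrogen. Among the measured compounds shown here, no measured step touches that position, so nothing beyond the scatter is expected for this assay here, and the step is estimated as a 1.2-fold higher number from compound 2 to compound 3 (0.07 log units; within the scatter). Compound 3 is therefore expected near 3500 nM, with a range from 1000 nM to 12000 nM.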

Compound 3, half-maximal inhibitory concentration: 4590 nM
Compound 3: the middle estimate sits 1.3-fold (0.12 log units) below what was measured; the range from low to high includes it.
By their numbers in this assay, from the lowest: compounds 2, 3 and 1 (each within the scatter of the next, the first and the last beyond it).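

In this assay, 3,4-difluorophenyl on the aromatic nitrogen gives a 1.5-fold higher number from compound 2 to compound 3 (0.19 log units; within the scatter). This pair therefore shows that, with the rest of compound 2 unchanged, this position tolerates the loss of the bromine and a new arrangement of fluorine without a change beyond the scatter. No evidence is at hand that bears on this result.

From the compounds shown here alone, whether an amine or a carboxylic acid on this phenyl ring would move the number beyond the scatter stays open. So does whether the same exchange behaves alike with the ether group of compound 1.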